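Lengthening the amide chain in a paw-edema series

The source may hold more compounds than are shown below. What is called first, only, known or untested is meant among the compounds shown, and "the series" means these compounds.

Three measured compounds share one core. Compound 1 `COc1cc2c(cc1OC)C(CC(=O)O)CC2` in a functional assay on the whole organism (strain Wistar) for inhibition, with Rattus norvegicus as the target, read by paw edema, with stated times of 60 min and 4 h, at a dose of 100 mg/kg by the oral route (on this read-out lower numbers stand for less inhibition and higher numbers for more inhibition at the one dose given (going by the name of the read-out)), gives 23.9%. Compound 2 `CNC(=O)CC1CCc2cc(OC)c(OC)cc21` gives 29.7%, and compound 3 `CCCNC(=O)CC1CCc2cc(OC)c(OC)cc21` gives 26.6%. Compound 2 holds the highest of the three numbers, yet the step of a number 5.8 percentage points higher from compound 1 to compound 2 (within the scatter) is within the scatter and compound 3 lies between the two, so the three effectively sit level. Compound 4 `CCCCNC(=O)CC1CCc2cc(OC)c(OC)cc21` is not yet measured and differs from compound 2 by propyl in place of hydrogen on a saturated chain carbon bound to an amide-type nitrogen. Among the compounds with values here, the one measured step that bears on this is a number 3.1 percentage points lower from compound 2 to compound 3 (within the scatter), a lengthening of the same chain that moved nothing beyond the scatter. A further lengthening is therefore expected to leave the read-out about where it stands, a number 1.7 percentage points lower from compound 2 to compound 4 (within the scatter). Compound 4 is estimated at 28%, between 18% and 38%.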

Compound 4, a percentage reported as inhibition, in the whole organism at one dose (the size of the read-out at that dose, not a potency): 25%
Estimate against measurement, compound 4: 3 percentage points above; low and high end bracket the measured number.
By their numbers in this assay, from the lowest: compounds 1, 4, 3 and 2 (each within the scatter of the next).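

Taking the chain on the amide nitrogen out to butylamino still does not move the reading in this assay: propyl in place of hydrogen gives a number 4.7 percentage points lower from compound 2 to compound 4 (within the scatter) and one further methyl gives a number 1.6 percentage points lower from compound 3 to compound 4 (within the scatter). Even against the parent carboxylic acid, the butyl amide shows only a number 1.1 percentage points higher from compound 1 to compound 4 (within the scatter), so neither chain length nor the swap from acid to amide separates these compounds. No measurement here gives a reason for this level picture.

As far as these compounds go, whether a chain longer than butyl, or a branched one such as isopropyl, would shift the reading remains open. So does the effect of a benzyl group or a basic amine at the end of the chain.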